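The source may report more compounds than this note shows. Statements on the series, on what has been measured and on what is new or still open speak of the compounds shown alone.

Measured in an ADME assay on L6 cells (Rattus norvegicus) for cytotoxicity, read by fluorescence and resazurin assay, with a stated time of 70 h; a higher number here means a weaker inhibitor, a lower number a stronger inhibitor:
Compound 1 `N=C(N)Nc1ccc2[nH]c(-c3ccccc3)nc2c1`: > 100 ug/mL (a limit)
Compound 2 `N#Cc1ccc(-c2nc3cc(NC(=N)N)ccc3[nH]2)cc1`: > 100 ug/mL (a limit)
Compound 3 `N=C(N)Nc1ccc2[nH]c(-c3ccc(C(=O)O)cc3)nc2c1`: > 100 ug/mL (a limit)

None of these three entries is an actual number. Compound 3 sits at the limit of > 100 ug/mL in this assay, at which 3 of the 3 values shown sit. Compound 4 `N=C(N)Nc1ccc2[nH]c(-c3ccc(OCc4ccccc4)cc3)nc2c1` carries benzyloxy in place of carboxy, para to a large group: benzyloxy in place of carboxy on an aromatic carbon. The measured changes on an aromatic carbon are a step that the two limits leave unreadable from compound 1 to compound 2, a step that the two limits leave unreadable from compound 1 to compound 3 and a step that the two limits leave unreadable from compound 2 to compound 3. For the measured compounds named here, none of them gives a size to carry over, and no measured compound has benzyloxy. A modest move toward a lower number in this assay is expected, though another limit is quite possible. The expected change is an at least 1.4-fold lower number from compound 3 to compound 4 (0.15 log units; that floor lies within the scatter). For compound 4 the estimated value is 70 ug/mL, with an expected range from 20 ug/mL to 100 ug/mL.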

Compound 4, half-maximal inhibitory concentration: 43.2 ug/mL
Compound 4: middle estimate off by 1.6-fold (0.21 log units), on the high side; low and high end bracket the measured number.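

In this assay compound 4 alone gives a number rather than a limit, so a change on this aromatic carbon, para to a large group, can now be given a size: the limit of > 100 ug/mL in this assay, at which 3 of the 4 values shown sit.

Benzyloxy gives an at least 2.3-fold lower number from compound 3 to compound 4 (0.36 log units; beyond the scatter) when it replaces carboxy, an at least 2.3-fold lower number from compound 2 to compound 4 (0.36 log units; beyond the scatter) when it replaces cyano, and an at least 2.3-fold lower number from compound 1 to compound 4 (0.36 log units; beyond the scatter) when it replaces hydrogen. The steps among compound 1, compound 2 and compound 3 cannot be read.

The compounds shown leave open whether the shift in compound 4 goes with the oxygen of benzyloxy or with its aromatic ring. A methoxy group or a phenyl group on that carbon would separate the two.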